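Adding a methyl to the chain of compound 3

A few compounds are considered here, and "the series" means these few. Any claim that something is new, unique, unknown or untested is made for them only; others in the source may bear on it.

In a functional assay on MCF7 cells (Homo sapiens) for inhibition, read by MTT assay, with a stated time of 72 h (on this read-out higher numbers stand for weaker inhibition and lower numbers for stronger inhibition), compound 3 (`C/C=C/C(=O)Nc1cccc(Oc2nc(Nc3cccc(OC)c3)nc3ccsc23)c1`) gives 14600 nM, the lower of the two numeric values in the series. Compound 1 (`COc1ccc(Nc2nc(Oc3cccc(NC(=O)C=C(C)C)c3)c3sccc3n2)cc1`) gives 46100 nM, a gap from compound 3 that lies beyond the scatter. Compound 2 (`COc1ccc(Nc2nc(Oc3cccc(NC(=O)/C=C/C(C)C)c3)c3sccc3n2)cc1`) reads > 50000 nM, which is a limit and not a number.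

Compound 4 (`CC/C=C/C(=O)Nc1cccc(Oc2nc(Nc3cccc(OC)c3)nc3ccsc23)c1`) differs from compound 3 in one place: methyl in place of hydrogen on a saturated chain carbon bound to a double-bonded chain carbon. This is methyl in place of hydrogen on a saturated chain carbon bound to a double-bonded chain carbon, turning prop-1-en-1-yl into but-1-en-1-yl. Among the compounds with values here, the only measured step within this chain is 3-methylbut-1-en-1-yl in place of 2-methylprop-1-en-1-yl on a carbonyl carbon, which gives an at least 1.0-fold higher number from compound 1 to compound 2 (0.03 log units; that floor lies within the scatter). That step ends at the limit of > 50000 nM in this assay, at which 1 of the 3 values shown sits, so it supplies a floor and no exact size. Compound 1 and compound 2 also differ from compound 3 outside this chain, so the step transfers only loosely. On this evidence, no step beyond the scatter is expected in this assay, with a slight lean toward weaker inhibition. The estimated step is a 1.4-fold higher number from compound 3 to compound 4 (0.14 log units; within the scatter). For compound 4 the estimated value is 20000 nM, with an expected range from 7000 nM to 48000 nM.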

Compound 4, half-maximal inhibitory concentration: 43400 nM
For compound 4 the middle estimate is 2.2-fold (0.34 log units) below the measured one; low and high end bracket the measured number.
By their numbers in this assay, from the lowest: compound 3; then compounds 4 and 1 (each within the scatter of the next). At a limit, above all of these: compound 2.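

In this assay, within the data shown here, turning prop-1-en-1-yl into but-1-en-1-yl gives a 3.0-fold higher number from compound 3 to compound 4 (0.47 log units; beyond the scatter), the first step on this chain with an exact size, and it lies beyond the scatter. Compound 2 stands at a limit and not at a number, so the earlier step on this chain supplied only a floor: the limit of > 50000 nM in this assay, at which 1 of the 4 values shown sits. The new step shows that, with the core of compound 3, one methyl on a saturated chain carbon bound to a double-bonded chain carbon is enough to weaken inhibition measurably, although this rests on one pair and gives no cause for the change.

Open, going by these compounds, is whether the trend continues with a longer chain such as pent-1-en-1-yl, or whether a hydroxyl or an amine on the same carbon would read like the methyl. Among these compounds, also open is whether the same methyl step would have a similar size with the core of compound 1, since no pair on that core carries this change.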